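The source may hold more compounds than are shown below. What is called first, only, known or untested is meant among the compounds shown, and "the series" means these compounds.

The compounds measured so far in a functional assay on A549 cells (Homo sapiens) for antiproliferative activity, read by MTT assay; on this read-out higher numbers stand for weaker inhibition and lower numbers for stronger inhibition:

Compound 1, `Cc1cccc(/C=N/Nc2ncc3c(n2)n(C2CCCC2)c(=O)c(=O)n3C)c1`, gives 34500 nM.
Compound 2, `Cn1c(=O)c(=O)n(C2CCCC2)c2nc(N/N=C/c3ccc(O)c(F)c3)ncc21`, gives 97800 nM.
Compound 3, `COc1cccc(/C=N/Nc2ncc3c(n2)n(C2CCCC2)c(=O)c(=O)n3C)c1`, gives 27400 nM.

Compound 2 stands highest of the three numbers in this assay. The step from compound 1 to compound 2 was a 2.8-fold higher number from compound 1 to compound 2 (0.45 log units; beyond the scatter), and the step from compound 2 to compound 3 was a 3.6-fold lower number from compound 2 to compound 3 (0.55 log units; beyond the scatter); both lie beyond the scatter. Compound 1 and compound 3, by contrast, sit close together, the step between them being a 1.3-fold lower number from compound 1 to compound 3 (0.10 log units; within the scatter).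

Compound 4, `CSc1ccc(/C=N/Nc2ncc3c(n2)n(C2CCCC2)c(=O)c(=O)n3C)cc1`, differs from compound 2 in one place: 4-(methylsulfanyl)phenyl in place of 3-fluoro-4-hydroxyphenyl on a carbon with a double bond to nitrogen. Both measured steps that touch compound 2 bear on this change, since each exchanged the 3-fluoro-4-hydroxyphenyl group for a phenyl ring carrying a single group, and each time the number fell by a modest amount, landing in the range shared by compound 1 and compound 3. Compound 4 likewise carries a phenyl ring with a single group, so a modest fall of similar size is expected, bringing it near compound 1 and compound 3 rather than leaving it with compound 2. Compound 4 is therefore estimated to give 32000 nM in this assay, with a range from 12000 nM to 80000 nM, which corresponds to an expected step of a 3.1-fold lower number from compound 2 to compound 4 (0.49 log units; beyond the scatter).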

Compound 4, half-maximal inhibitory concentration: 14100 nM
Compound 4: middle estimate off by 2.3-fold (0.36 log units), on the high side; the measured number falls inside the stated range.
By their numbers in this assay, from the lowest: compounds 4, 3 and 1 (each within the scatter of the next, the first and the last beyond it); then compound 2.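

In this assay, replacing 3-fluoro-4-hydroxyphenyl with 4-(methylsulfanyl)phenyl on this carbon with a double bond to nitrogen gives a 6.9-fold lower number from compound 2 to compound 4 (0.84 log units; beyond the scatter) and shows that a ring carrying a sulfur-containing group is accepted at this position. Comparison with the other two rings bearing a single group gives a split result: there is a 2.4-fold lower number from compound 1 to compound 4 (0.39 log units; beyond the scatter) but only a 1.9-fold lower number from compound 3 to compound 4 (0.29 log units; within the scatter) so 4-(methylsulfanyl)phenyl separates from 3-methylphenyl but not from 3-methoxyphenyl. Compound 2 now stands apart from all three other compounds, with each of its steps beyond the scatter, and it remains the weakest of the four in this assay.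

Still open, on these data alone, is how a ring bearing an amine, a carboxylic acid or a longer chain such as ethylsulfanyl would behave at this place. The exchange from compound 2 alters the fluorine, the hydroxy group and the methylsulfanyl group together, so their separate contributions cannot be told apart, and nothing available accounts for any of these steps.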